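Forecasting the 4-Acetylphenyl Analogue from Three Measured Compounds

This account rests on a few compounds, and the source may have more. Where it says the series, first, only, none or still open, it means among the compounds named here.

Compound 2 `COc1cc(-n2cnc3ccc(-c4cccc(F)c4)cc32)cc(OC)c1OC` gives 5270 nM in a functional assay on A549 cells (Homo sapiens) for antiproliferative activity, read by MTT assay, with a stated time of 72 h (a lower number here means a stronger inhibitor, a higher number a weaker inhibitor), the lowest of the three numbers shown, though compound 1 `COc1cc(-n2cnc3ccc(-c4ccc([N+](=O)[O-])cc4)cc32)cc(OC)c1OC` with 8940 nM and compound 3 `CCOc1ccc(-c2ccc3ncn(-c4cc(OC)c(OC)c(OC)c4)c3c2)cc1` with 8550 nM both stand within the scatter of it. Compound 4 `COc1cc(-n2cnc3ccc(-c4ccc(C(C)=O)cc4)cc32)cc(OC)c1OC` differs from compound 2 by 4-acetylphenyl in place of 3-fluorophenyl on an aromatic carbon. The measured steps that exchange this aryl group all stayed small: a 1.7-fold lower number from compound 1 to compound 2 (0.23 log units; within the scatter), a 1.6-fold higher number from compound 2 to compound 3 (0.21 log units; within the scatter) and a 1.0-fold lower number from compound 1 to compound 3 (0.02 log units; within the scatter). Three different groups on this aromatic carbon thus left the half-maximal inhibitory concentration unchanged beyond the scatter, so the step to 4-acetylphenyl is expected to be of the same kind, a 1.3-fold higher number from compound 2 to compound 4 (0.12 log units; within the scatter), with no direction favoured. Compound 4 is accordingly estimated at 7000 nM, within a range of 3000 nM to 17000 nM.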

Compound 4, half-maximal inhibitory concentration: 2510 nM
Beside the measured number, compound 4's estimate is 2.8-fold (0.45 log units) above it, outside the stated range (below it).
By their numbers in this assay, from the lowest: compound 4; then compounds 2, 3 and 1 (each within the scatter of the next).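

In this assay this aromatic carbon turns out not to be indifferent to its substituent: a 2.1-fold lower number from compound 2 to compound 4 (0.32 log units; beyond the scatter), a 3.4-fold lower number from compound 3 to compound 4 (0.53 log units; beyond the scatter) and a 3.6-fold lower number from compound 1 to compound 4 (0.55 log units; beyond the scatter) all lie beyond the scatter, unlike any earlier step. That makes compound 4 the strongest of the four, with the acetyl-bearing aryl group the only one here to separate from the others. Nothing shown explains why acetyl differs from the other groups.

On these data alone, whether a carboxylic acid, an amine or a longer ketone chain in place of acetyl would keep this number remains open.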